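The source may report more compounds than this note shows. Statements on the series, on what has been measured and on what is new or still open speak of the compounds shown alone.

Three compounds share one core and differ only in the group carried on an amine nitrogen in a ring. Compound 1 is `CN1CCN(CC(=O)Nc2nc3ccccc3[nH]2)CC1`, compound 2 is `CCN1CCN(CC(=O)Nc2nc3ccccc3[nH]2)CC1` and compound 3 is `O=C(CN1CCN(c2ccccc2F)CC1)Nc1nc2ccccc2[nH]1`. In a functional assay, read by spectrophotometry, with a stated time of 30 min, tested at 200 ug/mL (a lower number here means a weaker effect, a higher number a stronger effect of the compound at the concentration tested), compound 1 gives 61.6%, compound 2 gives 65.8% and compound 3 gives 70.6%. Compound 3 carries the largest of these three numbers, yet the steps of a number 9 percentage points higher from compound 1 to compound 3 (within the scatter) and a number 4.8 percentage points higher from compound 2 to compound 3 (within the scatter) both lie within the scatter, as does a number 4.2 percentage points higher from compound 1 to compound 2 (within the scatter), so the three compounds cannot be told apart on this measurement.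

Compound 4 is `O=C(CN1CCN(c2ccccn2)CC1)Nc1nc2ccccc2[nH]1`. It differs from compound 3 in one place: pyridin-2-yl in place of 2-fluorophenyl on an amine nitrogen in a ring. The two measured steps that bear on this change are those that also swap the group on the amine nitrogen in a ring, a number 9 percentage points higher from compound 1 to compound 3 (within the scatter) and a number 4.8 percentage points higher from compound 2 to compound 3 (within the scatter), and neither moved the number beyond the scatter. On that basis no step beyond the scatter is expected in this assay for compound 4, and the expected step is a number 2.6 percentage points lower from compound 3 to compound 4 (within the scatter). Compound 4 is therefore estimated to give 68%, with a range from 56% to 80%.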

Compound 4, a percentage reported as activity, at one concentration (the size of the read-out at that concentration, not a potency): 76.2%
Compound 4: middle estimate off by 8.2 percentage points, on the low side, within the range that was stated.
By their numbers in this assay, from the lowest: compounds 1, 2, 3 and 4 (each within the scatter of the next, the first and the last beyond it).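

Replacing 2-fluorophenyl with pyridin-2-yl on the amine nitrogen in a ring gives a number 5.6 percentage points higher from compound 3 to compound 4 (within the scatter) in this assay and so leaves these two aromatic groups indistinguishable on this measurement. The new information lies in the comparisons with the small alkyl groups: pyridin-2-yl in place of ethyl gives a number 10.4 percentage points higher from compound 2 to compound 4 (beyond the scatter) and pyridin-2-yl in place of methyl gives a number 14.6 percentage points higher from compound 1 to compound 4 (beyond the scatter), so this position can shift the read-out beyond the scatter, if only modestly, whereas compound 3 goes against any rule that an aromatic group on this nitrogen is enough, since its steps from compound 1 and compound 2 stay within the scatter. Nothing measured here explains this difference, so the hydrogen-bond acceptor counted on pyridin-2-yl cannot be credited with it.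

A plain phenyl group on the same nitrogen would help to show whether compound 3 and compound 4 owe their numbers to the aromatic ring itself or to the fluorine and the ring nitrogen that set them apart. As far as these compounds go, whether pyridin-3-yl or pyridin-4-yl would match pyridin-2-yl remains open as well, and each number here describes a single concentration rather than a potency.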